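The compounds below may be only part of what the source reports. "The series", "measured", "known", "first", "only" and "open" are said of these compounds alone.

Working notes on the series, read in a functional assay on MCF7 cells (Homo sapiens) for antiproliferative activity, read by MTT assay, with a stated time of 72 h; a lower number here means a stronger inhibitor, a higher number a weaker inhibitor. Compound 1 `CC1=CC[C@H]2[C@@H]1CC=C(C)[C@@H](CCC1=C(C)CC[C@@H]3OC(C)(C)[C@@H](O)CC[C@@]13C)C2(C)C` gives > 50000 nM, which is a limit and not a number. Among the measured compounds shown here, compound 2 `CC(=O)O[C@H]1CC[C@]2(C)[C@H](CC[C@@](C)(O)[C@H]2CC[C@@H]2C(C)=CC[C@H]3[C@H](CC[C@]3(C)OC(C)=O)C2(C)C)OC1(C)C` gives 39200 nM, the only true number so far. Compound 3 `CC1=CC[C@H]2[C@H](CC[C@]2(C)O)C(C)(C)[C@@H]1CC[C@H]1[C@]2(C)CC[C@H](OC(=O)CCC(=O)O)C(C)(C)O[C@H]2CC[C@@]1(C)O` gives > 50000 nM, which is also a limit and not a number. As far as these compounds go, compound 3 therefore stands with compound 1 at the limit of > 50000 nM in this assay, at which 2 of the 3 values shown sit, so its real potency in this assay is unknown.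

Compound 4 `CC1=CC[C@H]2[C@H](CC[C@]2(C)O)C(C)(C)[C@@H]1CC[C@H]1[C@]2(C)CC[C@H](OC(=O)c3ccc(C)cc3)C(C)(C)O[C@H]2CC[C@@]1(C)O` keeps the shared core of compound 3 and changes one group: 4-methylphenyl in place of 2-carboxyethyl on a carbonyl carbon. In words, 4-methylphenyl stands in place of 2-carboxyethyl on a carbonyl carbon, so a six-membered aromatic ring of carbon only enters and the hydrogen-bond donor of the leaving group goes.

For the measured compounds named here, no measured pair isolates this change, so the expectation is loose. Compound 2, at 39200 nM, shows that a number can be reached on this core. A modest move toward stronger inhibition is expected, with a repeat of the limit a real possibility. The estimated size of the change, an at least 1.7-fold lower number from compound 3 to compound 4 (0.25 log units; that floor lies within the scatter), is only approximate, since its starting point is a limit. For compound 4 the expected value is 28000 nM, with an estimated range of 10000 nM to 50000 nM.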

Compound 4, half-maximal inhibitory concentration: > 50000 nM
Compound 4: a limit, no number; the forecaster's own chance of this, stated with the estimate: 40%; middle value at least 1.7-fold (0.25 log units) away from the limit.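

Compound 4 gives > 50000 nM, which is a limit and not a number. Compound 3 also stands at a limit, so the change from compound 3 to compound 4 gives no readable step: the limit of > 50000 nM in this assay, at which 3 of the 4 values shown sit.

The compounds shown leave open whether 4-methylphenyl in place of 2-carboxyethyl on a carbonyl carbon shifts the real potency at all.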